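A Phenyl for a Methyl at the Limit of Tolerance

The source may report more compounds than this note shows. Statements on the series, on what has been measured and on what is new or still open speak of the compounds shown alone.

In an ADME assay on H9c2 cells (Rattus norvegicus) for cytotoxicity, read by resazurin assay, with a stated time of 72 h (a higher number here means that more compound is tolerated, a lower number that less compound is tolerated), compound 1 `C/C(=N\Nc1nc(CCl)cs1)c1ccc(Cl)c(Cl)c1` gives > 50000 nM as a limit of the assay. Compound 2 `C/C(=N\Nc1nc(C)c(C)s1)c1ccc(Cl)c(Cl)c1` gives > 50000 nM as a limit too. Compound 3 `C/C(=N\N=c1\scc(-c2ccccc2)n1C)c1ccc(Cl)c(Cl)c1` gives > 50000 nM as a limit as well, so it has no exact number. Among the measured compounds shown here, the three compounds share the limit of > 50000 nM in this assay, at which 3 of the 3 values shown sit, and no measured step connects them. Compound 4 `C/C(=N\N=c1\scc(-c2ccccc2)n1-c1ccccc1)c1ccc(Cl)c(Cl)c1` carries phenyl in place of methyl on an aromatic nitrogen. For the measured compounds named here, with no measured step to draw on, the expected result in this assay is a number no higher from compound 3 to compound 4 (the limit leaves the size open) and no shift beyond the scatter in either direction. For compound 4 the estimated value is 50000 nM (expected range 25000 nM to 100000 nM).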

Compound 4, half-maximal cytotoxic concentration: > 50000 nM
Compound 4: only a limit was reported; the forecaster's own chance of this, stated with the estimate: 70%; the middle value lies on the limit itself.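

In this assay, among the compounds shown here, compound 3 and compound 4 both stand at a limit, and no step between them can be read. The compounds shown leave open how much of either is tolerated past that limit.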